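The source may report more compounds than this note shows. Statements on the series, on what has been measured and on what is new or still open speak of the compounds shown alone.

Measured so far in an assay on HEK293 cells for inhibition of Steryl-sulfatase (Homo sapiens), tested at 1 uM; a higher number here means a stronger effect of the compound at the concentration tested, a lower number a weaker effect:
compound 1 `CCN(Cc1cccc(Br)c1)c1ccc(C(=O)N2CCc3ccc(OS(N)(=O)=O)cc3C2)cc1` gives 97.2%
compound 2 `CC(C)CCN(CCC(C)C)c1ccc(C(=O)N2CCc3ccc(OS(N)(=O)=O)cc3C2)cc1` gives 90.8%
compound 3 `CCN(Cc1ccccc1)c1ccc(C(=O)N2CCc3ccc(OS(N)(=O)=O)cc3C2)cc1` gives 83.6%

Compound 3 holds the lowest of the three numbers in this assay. Its gap to compound 2 is within the scatter a number 7.2 percentage points lower from compound 2 to compound 3 (within the scatter), while the gap to compound 1 lies beyond it a number 13.6 percentage points lower from compound 1 to compound 3 (beyond the scatter).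

Compound 4 `NS(=O)(=O)Oc1ccc2c(c1)CN(C(=O)c1ccc(N(Cc3ccccc3)Cc3ccco3)cc1)CC2` differs from compound 3 in one place: furan-2-yl in place of methyl on a saturated chain carbon bound to a nitrogen on an aromatic ring. Among the compounds with values here, no measured step alters exactly this position. The nearest precedents are the exchanges of the whole amine substituent, a number 6.4 percentage points lower from compound 1 to compound 2 (within the scatter) and a number 7.2 percentage points lower from compound 2 to compound 3 (within the scatter), both within the scatter, and the bromo removal a number 13.6 percentage points lower from compound 1 to compound 3 (beyond the scatter), which was modest. Within the data shown here, every compound so far sits high in this assay, so compound 4 is expected to stay in that region, with a step of a number 3.4 percentage points higher from compound 3 to compound 4 (within the scatter) that is estimated to be small. Compound 4 is therefore expected to give about 87%, with a range from 76% to 96%.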

Compound 4, a percentage reported as inhibition, at one concentration (the size of the read-out at that concentration, not a potency): 98.2%
Compound 4: the middle estimate sits 11.2 percentage points below what was measured, outside the stated range (above it).
By their numbers in this assay, from the lowest: compounds 3, 2, 1 and 4 (each within the scatter of the next, the first and the last beyond it).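

In this assay, replacing ethyl with (furan-2-yl)methyl gives a step beyond the scatter, a number 14.6 percentage points higher from compound 3 to compound 4 (beyond the scatter), the first change measured at this position alone. The position therefore takes a five-membered aromatic ring carrying one hetero atom, and the number rises. Nothing in the data shown explains this rise. As far as these compounds go, it remains open whether the ring oxygen or simply the larger group matters. A thiophen-2-yl or cyclopentyl group in the same place would separate these two readings.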